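From Dichlorophenyl to Difluorobenzyl on a Shared Core

The compounds below may be only part of what the source reports. "The series", "measured", "known", "first", "only" and "open" are said of these compounds alone.

Three measured compounds share one core and differ on one saturated ring carbon. In a physicochemical assay for lipophilicity, measured as chromatographic lipophilicity, at pH 7.4 (on this read-out lower numbers stand for lower lipophilicity and higher numbers for higher lipophilicity), compound 1 `COc1cc(-c2nnc3n2CCCC3c2ccc(Cl)c(Cl)c2)ccc1-c1cnc(C)o1` gives 3.2, compound 2 `COc1cc(-c2nnc3n2CCCC3(O)c2ccc(Cl)c(Cl)c2)ccc1-c1cnc(C)o1` gives 2.9, and compound 3 `COc1cc(-c2nnc3n2CCCC3(c2ccc(Cl)c(Cl)c2)C(C)(C)O)ccc1-c1cnc(C)o1` gives 3.7. Compound 3 therefore has the highest of the three numbers, clear of the scatter from both others.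

Compound 4 `COc1cc(-c2nnc3n2CCCC3(Cc2ccc(F)c(F)c2)C(C)(C)O)ccc1-c1cnc(C)o1` has not yet been measured. It differs from compound 3 in one place, where 3,4-difluorobenzyl stands in place of 3,4-dichlorophenyl on a saturated ring carbon (3,4-difluorobenzyl in place of 3,4-dichlorophenyl on a saturated ring carbon).

The measured steps involve other groups. Hydroxy in place of hydrogen gives a number 0.30 log units lower from compound 1 to compound 2 (within the scatter), 1-hydroxy-1-methylethyl in place of hydrogen gives a number 0.50 log units higher from compound 1 to compound 3 (beyond the scatter), and 1-hydroxy-1-methylethyl in place of hydroxy gives a number 0.80 log units higher from compound 2 to compound 3 (beyond the scatter). All three compounds keep 3,4-dichlorophenyl, so these steps offer only a rough scale and no direct test of the new group. The direction expected here is a judgement from the structural change alone, and it is a small move downward in this assay. The expected change is a number 0.30 log units lower from compound 3 to compound 4 (within the scatter), which may not clear the scatter. For compound 4 the estimate is 3.4, with an expected range from 3 to 3.8.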

Compound 4, distribution coefficient: 3
Compound 4: the middle estimate sits 0.40 log units above what was measured; the measured number falls inside the stated range.
By their numbers in this assay, from the lowest: compounds 2, 4 and 1 (each within the scatter of the next); then compound 3.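

For the compounds shown here, until this result, all the compounds carried 3,4-dichlorophenyl, and only the other group on the saturated ring carbon had been varied; compound 4 shows that changing the aromatic group at this position can also shift the reading in this assay, with a number 0.70 log units lower from compound 3 to compound 4 (beyond the scatter) a modest step beyond the scatter. Both groups contain one six-membered aromatic ring of carbon only, with no hydrogen-bond donors or acceptors and no net charge, so the shift occurs without any change in those counted features, although this single step replaces chlorine with fluorine and phenyl with benzyl at once. No supporting information here accounts for the shift.

The compounds shown leave open how much of the step belongs to the halogen and how much to the benzyl form, a question that 3,4-dichlorobenzyl or 3,4-difluorophenyl at the same carbon could help to separate. They also leave open whether 3,4-difluorobenzyl would give a similar step with hydrogen or hydroxy on that carbon in place of 1-hydroxy-1-methylethyl.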